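A few compounds are considered here, and "the series" means these few. Any claim that something is new, unique, unknown or untested is made for them only; others in the source may bear on it.

In an ADME assay on MT4 cells (Homo sapiens) for cytotoxicity, read by MTT assay (on this read-out lower numbers stand for higher toxicity in this test and higher numbers for lower toxicity in this test), compound 1 `Cc1c(Cc2c(F)cccc2F)nc(SCc2ccc([N+](=O)[O-])cc2)[nH]c1=O` gives > 37000 nM, a limit of the assay and not a number. Compound 2 `Cc1ccc(CSc2nc(Cc3c(F)cccc3F)c(C)c(=O)[nH]2)c(C)c1` gives > 65000 nM, again a limit, so its standing is known only as a limit. Compound 3 `Cc1cc(C)cc(CSc2nc(Cc3c(F)cccc3F)c(C)c(=O)[nH]2)c1` differs from compound 2 through 3,5-dimethylphenyl in place of 2,4-dimethylphenyl on a saturated chain carbon bound to a sulfur. The two have the same atoms, joined differently. Among the measured compounds shown here, the one measured step at this place is a step that the two limits leave unreadable from compound 1 to compound 2, so it offers no size to carry over. The expectation therefore rests on compound 2, whose result of > 65000 nM is a limit, and it is for no step beyond the scatter in this assay, in either direction. The estimated step is a number no higher from compound 2 to compound 3 (the limit leaves the size open). For compound 3 the estimated value is 65000 nM, with an expected range from 25000 nM to 150000 nM, and the result may again be only a limit.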

Compound 3, half-maximal cytotoxic concentration: > 65000 nM
Compound 3: only a limit was reported; the forecaster's own chance of this, stated with the estimate: 70%; the middle value lies on the limit itself.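

In this assay, among the compounds shown here, the results for compound 1, compound 2 and compound 3 are all limits and not numbers, so no step between them can be read. The compounds shown leave open where each true value lies, and whether 4-nitrophenyl, 2,4-dimethylphenyl and 3,5-dimethylphenyl differ at all.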